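The compounds below may be only part of what the source reports. "The series", "measured", "known", "first", "only" and "open" are said of these compounds alone.

Three compounds share one core and have been measured in a physicochemical assay for solubility, read by HPLC, with a stated time of 24 h; a higher number here means a more soluble compound, a lower number a less soluble compound:

Compound 1 `CCN1CCN(C[C@H]2CN(c3ccc(-n4cc(-c5ccccn5)cn4)c(F)c3)C(=O)O2)CC1` gives 706000 nM

Compound 2 `COC(=O)NC[C@H]1CN(c2ccc(-n3cc(-c4ccccn4)cn3)c(F)c2)C(=O)O1` gives 34100 nM

Compound 3 `O=C1O[C@@H](CNC(=O)C(F)(F)F)CN1c1ccc(-n2cc(-c3ccccn3)cn2)c(F)c1` gives 114000 nM

Compound 1 has the highest number of the three, and both of its steps to the others lie beyond the scatter: a 21-fold lower number from compound 1 to compound 2 (1.32 log units; beyond the scatter) and a 6.2-fold lower number from compound 1 to compound 3 (0.79 log units; beyond the scatter). Between the two smaller compounds the order is a 3.3-fold higher number from compound 2 to compound 3 (0.52 log units; beyond the scatter).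

Compound 4 `NC(=O)[C@H]1CN(c2ccc(-n3cc(-c4ccccn4)cn3)c(F)c2)C(=O)O1` has not yet been measured. Compared with compound 1 it carries carbamoyl in place of (4-ethylpiperazin-1-yl)methyl on a saturated ring carbon. The two measured steps that bear on this are those from compound 1, in which the same 4-ethylpiperazin-1-yl piece was removed and a neutral carbonyl-bearing group put in its place; both gave a clear drop, one modest and one large. The step to compound 4 is therefore expected to be a drop as well, most likely between those two in size, a 12-fold lower number from compound 1 to compound 4 (1.07 log units; beyond the scatter). For compound 4 in this assay the estimated value is 60000 nM, with a likely range from 15000 nM to 250000 nM.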

Compound 4, solubility: 27200 nM
Compound 4: the middle estimate sits 2.2-fold (0.34 log units) above what was measured, within the range that was stated.
By their numbers in this assay, from the lowest: compounds 4 and 2 (each within the scatter of the next); then compound 3; then compound 1.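

In this assay, compound 4 places carbamoyl directly on the saturated ring carbon next to the ring oxygen, and replacing the (4-ethylpiperazin-1-yl)methyl group with this much smaller group gives a large step (a 26-fold lower number from compound 1 to compound 4 (1.41 log units; beyond the scatter)). Carbamoyl and ((methoxycarbonyl)amino)methyl cannot be told apart at this position (a 1.3-fold lower number from compound 2 to compound 4 (0.10 log units; within the scatter)), whereas the (((trifluoromethyl)carbonyl)amino)methyl group keeps a clear lead over carbamoyl (a 4.2-fold lower number from compound 3 to compound 4 (0.62 log units; beyond the scatter)), so the outcome here depends on more than the size of the group. Nothing available explains any of these steps.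

As far as these compounds go, it remains open whether the high number of compound 1 belongs to the ethylpiperazine ring or to the amine nitrogens within it. A simple aminomethyl group, a morpholine ring on the same chain carbon or a carboxylic acid on the ring carbon would help separate these possibilities.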